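Sulfonyl Replaces Carbonyl on the Ring Nitrogen

This account rests on a few compounds, and the source may have more. Where it says the series, first, only, none or still open, it means among the compounds named here.

Of the compounds shown here, two of a shared core have so far been tested in a functional assay on MDA-MB-231 cells (Homo sapiens) for inhibition, read by sulforhodamine B assay, tested at 10 uM; on this read-out higher numbers stand for more inhibition at the one concentration tested (going by the name of the read-out) and lower numbers for less inhibition. Compound 1 `CN(C)c1ccc(C2CC(c3ccc(-n4cncn4)cc3)=NN2)cc1` gives 7% in this assay. Compound 2 `CN1CCN(c2ccc(C3=NN(C(=O)/C=C/c4ccccc4)C(c4ccc(N(C)C)cc4)C3)cc2)CC1` gives 35.9%, the higher of the two numbers, and compound 1 lies beyond the usual scatter below it. Compound 3 `CN1CCN(c2ccc(C3=NN(S(=O)(=O)c4ccc(C#N)cc4)C(c4ccc(N(C)C)cc4)C3)cc2)CC1` has not yet been measured. It differs from compound 2 in one place: (4-cyanophenyl)sulfonyl in place of (2-phenylethenyl)carbonyl on an amine nitrogen in a ring. Among the compounds with values here, no measured pair shows what this kind of swap on an amine nitrogen in a ring does to the reading, so the direction of the step is open and the two measured numbers span only a modest range. Compound 3 is therefore expected to stay near compound 2 in this assay. The step of a number 2.9 percentage points lower from compound 2 to compound 3 (within the scatter) is expected to be small, none beyond the scatter. Compound 3 is estimated at 33%, with a range from 10% to 60%.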

Compound 3, a percentage reported as inhibition, at one concentration (the size of the read-out at that concentration, not a potency): 99.8%
Compound 3: middle estimate off by 66.8 percentage points, on the low side, and the stated range ends below it.
By their numbers in this assay, from the lowest: compound 1; then compound 2; then compound 3.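

In this assay the group on the amine nitrogen in the ring of the shared core proves to matter a great deal: (4-cyanophenyl)sulfonyl in place of (2-phenylethenyl)carbonyl gives a number 63.9 percentage points higher from compound 2 to compound 3 (beyond the scatter) with the rest of the molecule unchanged. Within the data shown here, this is the first single-place comparison, and it shows that this one position can move the reading far, which the two earlier compounds, differing in several places, could not show. Nothing available bears on why the reading rises so strongly.

Going by these compounds, the swap changes the carbonyl to a sulfonyl and replaces the phenylethenyl part with a 4-cyanophenyl ring at the same time, so the share of each change stays open. A phenylsulfonyl group or a (4-cyanophenyl)carbonyl group at this position would separate the two.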